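This account rests on a few compounds, and the source may have more. Where it says the series, first, only, none or still open, it means among the compounds named here.

Measured so far:
- compound 1, `O=C(O)CCNC(=O)c1ccc(CN(c2ccc(C3=CCCCC3)cc2)c2nc(-c3ccc(Cl)cc3)c(-c3ccccc3)s2)cc1`: 1000 nM
- compound 2, `O=C(O)CCNC(=O)c1ccc(CC(c2ccc(Cl)cc2)c2nc(-c3ccc(OC(F)(F)F)cc3)cs2)cc1`: 429 nM
- compound 3, `Cc1cc(N(Cc2ccc(C(=O)NCCC(=O)O)cc2)c2nc(-c3ccc(C(F)(F)F)cc3)cs2)ccc1C(C)C`: 633 nM

All three numbers come from an in vitro assay on BHK cells for displacement of a labelled ligand from gastric inhibitory polypeptide receptor (Homo sapiens), read by scintillation proximity assay; on this read-out lower numbers stand for stronger inhibition and higher numbers for weaker inhibition. Compound 3 gives 633 nM, which is the second highest of the three; its nearest neighbour is compound 2 with 429 nM, and the furthest is compound 1 with 1000 nM. Both gaps lie within the usual scatter of this assay, so the three compounds cannot be ranked against one another on these numbers alone.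

Compound 4, `O=C(O)CCNC(=O)c1ccc(CN(c2ccc(OC(F)(F)F)cc2)c2nc(-c3ccc(C(F)(F)F)cc3)cs2)cc1`, has not been measured. It differs from compound 3 in one place: 4-(trifluoromethoxy)phenyl in place of 4-isopropyl-3-methylphenyl on a nitrogen on an aromatic ring. Going by the values given here, no pair of measured compounds differs by exactly this change, so there is no measured step to lean on; the only guide is that the three compounds, despite several differences among them, all sit close together in this assay.

With that in mind, the step from compound 3 to compound 4 is expected to be small, a 1.3-fold higher number from compound 3 to compound 4 (0.10 log units; within the scatter), not clearly beyond the scatter in either direction. Compound 4 is therefore estimated to give about 800 nM in this assay, most likely somewhere between 250 nM and 2500 nM.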

Compound 4, half-maximal inhibitory concentration: 833 nM
Compound 4: the middle estimate sits 1.0-fold (0.02 log units) below what was measured, within the range that was stated.
By their numbers in this assay, from the lowest: compounds 2, 3, 4 and 1 (each within the scatter of the next, the first and the last beyond it).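

Going by these compounds alone, changing the group on this nitrogen from 4-isopropyl-3-methylphenyl to 4-(trifluoromethoxy)phenyl gives a 1.3-fold higher number from compound 3 to compound 4 (0.12 log units; within the scatter) in this assay and is the first comparison here in which only one place differs. At this place, an all-carbon group and one carrying oxygen and fluorine therefore give readings that cannot be told apart, even though the incoming group has one hydrogen-bond acceptor and the outgoing group has none. The data shown offer no measured explanation for this similarity.

From the compounds shown here alone, compounds 1, 3 and 4 all carry a substituted phenyl ring on this nitrogen, so it remains open whether a phenyl ring bearing an amine, a saturated cyclohexyl ring or a plain butyl chain there would also give a reading in the same range. All the compounds shown also end in the same carboxylic acid chain, so the effect of a primary amide or a tetrazole in place of the acid remains unknown.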